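Bromo in place of fluoro: notes on compound 2

The compounds below may be only part of what the source reports. "The series", "measured", "known", "first", "only" and "open" are said of these compounds alone.

compound 1 `O=C1/C(=C/c2ccc(F)cc2)CCc2ccccc21`: 49300 nM
compound 2 `O=C1CCCCC/C1=C\c1cccc(F)c1`: 382000 nM

In a functional assay on L1210 cells (Mus musculus) for inhibition (on this read-out higher numbers stand for weaker inhibition and lower numbers for stronger inhibition), compound 2 gives 382000 nM and stands highest of the two numbers, on the weaker side of compound 1 by a gap beyond the usual scatter. The two compounds differ in more than one place, so that gap gives no measure of a single swap.

Compound 3 `O=C1CCCCC/C1=C\c1cccc(Br)c1` has bromo in place of fluoro on an aromatic carbon. For the measured compounds named here, no measured pair shows this swap. The expectation rests on compound 2 alone, whose value (382000 nM) leaves more room downward than upward. A small move toward stronger inhibition is expected (a 1.9-fold lower number from compound 2 to compound 3 (0.28 log units; within the scatter)), possibly not beyond the scatter. Compound 3 is estimated at 200000 nM in this assay, with an expected range from 80000 nM to 450000 nM.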

Compound 3, half-maximal inhibitory concentration: 246000 nM
Compound 3: middle estimate off by 1.2-fold (0.09 log units), on the low side; the range from low to high includes it.
By their numbers in this assay, from the lowest: compound 1; then compounds 3 and 2 (each within the scatter of the next).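

For the compounds shown here, on the aromatic carbon of this six-membered aromatic ring, bromo in place of fluoro gives the first single-place reading: in this assay the swap gives a 1.6-fold lower number from compound 2 to compound 3 (0.19 log units; within the scatter) and so leaves the two compounds without an order. Each group is one heavy atom with no hydrogen-bond donors or acceptors, so the reading covers only an exchange of one halogen for the other at this place. Nothing measured on hand accounts for the size of this step.

As far as these compounds go, whether an amine, a carboxylic acid or a longer chain on the same carbon would shift the number beyond the scatter remains open. Also open, from the compounds shown here alone, is whether the same swap would read alike on the core of compound 1, and which of its differences from compound 2 carries their gap.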